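Quinoline amide series: aryl swap at the ring carbon

The source may report more compounds than this note shows. Statements on the series, on what has been measured and on what is new or still open speak of the compounds shown alone.

Working notes. Compound 2 `COc1cc2c(Oc3ccc(NC(=O)c4cc(-c5cccc(Cl)c5)nc5ccc(F)cc45)cc3F)ccnc2cc1OCCCN1CCCC1` gives 72 nM in a functional assay on NCI-H460 cells (Homo sapiens) for cytotoxicity, read by MTT assay, with a stated time of 72 h (a lower number here means a stronger inhibitor, a higher number a weaker inhibitor), the lowest of the two numbers in hand; compound 1 `COc1ccc(-c2cc(C(=O)Nc3ccc(Oc4ccnc5cc(OCCCN6CCCCC6)c(OC)cc45)c(F)c3)c3cc(F)ccc3n2)cc1` gives 240 nM there, a gap beyond the scatter. Compound 3 `COc1ccc(-c2cc(C(=O)Nc3ccc(Oc4ccnc5cc(OCCCN6CCCC6)c(OC)cc45)c(F)c3)c3cc(F)ccc3n2)cc1` is not yet measured. It differs from compound 2 in one place: 4-methoxyphenyl in place of 3-chlorophenyl on an aromatic carbon. The expected step of a 2.5-fold higher number from compound 2 to compound 3 (0.40 log units; beyond the scatter) is a weakening beyond the scatter, since compound 1, which also carries the 4-methoxyphenyl, gives 240 nM. Compound 3 is therefore estimated at 180 nM, with a range from 80 nM to 400 nM.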

Compound 3, half-maximal inhibitory concentration: 250 nM
Beside the measured number, compound 3's estimate is 1.4-fold (0.14 log units) below it; the range from low to high includes it.
By their numbers in this assay, from the lowest: compound 2; then compounds 1 and 3 (each within the scatter of the next).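

In this assay the aryl group on the aromatic carbon next to the ring nitrogen can now be read alone: 4-methoxyphenyl in place of 3-chlorophenyl gives a 3.5-fold higher number from compound 2 to compound 3 (0.54 log units; beyond the scatter) on an otherwise unchanged structure. With 4-methoxyphenyl held fixed, pyrrolidin-1-yl in place of piperidin-1-yl gives a 1.0-fold higher number from compound 1 to compound 3 (0.02 log units; within the scatter), so that change does not register in this pair. Nothing in hand accounts for the aryl step.

The swap moves the substituent and changes it at once, so 3-methoxyphenyl or 4-chlorophenyl would be needed to separate the two. On these data alone, whether the piperidin-1-yl result holds alongside 3-chlorophenyl also stays open.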